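Selenium in place of sulfur: an expected assay limit

The source may report more compounds than this note shows. Statements on the series, on what has been measured and on what is new or still open speak of the compounds shown alone.

Compound 1 `CS/C(=N\C(=O)c1csc([N+](=O)[O-])c1)NC(=O)c1csc([N+](=O)[O-])c1` in a functional assay on HT-29 cells (Homo sapiens) for cytotoxicity, read by MTT assay, with a stated time of 72 h (on this read-out higher numbers stand for weaker inhibition of growth and lower numbers for stronger inhibition of growth), gives > 100000 nM, which is a limit of the assay and not a number.
Compound 2 `C[Se]/C(=N\C(=O)c1ccco1)NC(=O)c1ccco1` in this assay gives > 100000 nM, again a limit.
Compound 3 `O=C(/N=C(/NC(=O)c1cc2ccccc2s1)[Se]Cc1ccccc1)c1cc2ccccc2s1` in this assay gives > 100000 nM, likewise a limit.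

Compound 1 stands at the limit reported for every measured value, as summed up in the limit of > 100000 nM in this assay, at which 3 of the 3 values shown sit. For the measured compounds named here, no step between two measured compounds is recorded, so no measured change in growth inhibition can be described among them.

Compound 4 `C[Se]/C(=N\C(=O)c1csc([N+](=O)[O-])c1)NC(=O)c1csc([N+](=O)[O-])c1` differs from compound 1 by one change, a group of 2 heavy atoms (1 carbon, 1 selenium; no ring) in place of a group of 2 heavy atoms (1 carbon, 1 sulfur; no ring), on a carbon with a double bond to nitrogen.

For this step he expects no movement beyond the scatter in this assay, since compound 2 already carries selenium on the same kind of carbon and gives > 100000 nM. His estimate for compound 4 is 100000 nM, between 50000 nM and 200000 nM, and the expected step of a number no higher from compound 1 to compound 4 (the limit leaves the size open) most likely ends at the same limit.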

Compound 4, concentration for total growth inhibition: > 100000 nM
Compound 4 gave a limit, no number; the forecaster's own chance of this, stated with the estimate: 85%; the middle value sits exactly at the limit.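

In this assay compound 4 gives > 100000 nM, a limit and not a number. Compound 1 also stands at a limit, so no step between compound 1 and compound 4 can be read: the limit of > 100000 nM in this assay, at which 4 of the 4 values shown sit.

The compounds shown leave open whether selenium in place of sulfur changes growth inhibition at all.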